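The source may hold more compounds than are shown below. What is called first, only, known or untested is meant among the compounds shown, and "the series" means these compounds.

Compound 1 `O=C(Cc1cccnc1)c1cc2ccccc2[nH]1`: 65000 nM
Compound 2 `COc1cccc2[nH]c(C(=O)Cc3cccnc3)cc12`: 58000 nM

In an assay on isolated protein for inhibition of Indoleamine 2,3-dioxygenase 1 (Homo sapiens), read by spectrophotometry (on this read-out lower numbers stand for stronger inhibition and higher numbers for weaker inhibition), compound 2 and compound 1 sit within the scatter of each other, the step of a 1.1-fold lower number from compound 1 to compound 2 (0.05 log units; within the scatter) being too small to rank them. Compound 3 `O=C(Cc1cccnc1)c1cc2c(F)cccc2[nH]1` carries fluoro in place of methoxy on an aromatic carbon. Among the measured compounds shown here, the only measured step that bears on this position, a 1.1-fold lower number from compound 1 to compound 2 (0.05 log units; within the scatter), changed the number by less than the scatter, so a further exchange at the same aromatic carbon is expected to leave the number essentially unchanged, with no step beyond the scatter in either direction, that is a 1.0-fold higher number from compound 2 to compound 3 (0.01 log units; within the scatter). Compound 3 is therefore estimated at 60000 nM, within 30000 nM to 120000 nM.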

Compound 3, half-maximal inhibitory concentration: 153000 nM
Estimate against measurement, compound 3: 2.6-fold (0.41 log units) below, outside the stated range (above it).
By their numbers in this assay, from the lowest: compounds 2 and 1 (each within the scatter of the next); then compound 3.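

At this aromatic carbon the choice of group does register in this assay: fluoro weakens inhibition relative to methoxy (a 2.6-fold higher number from compound 2 to compound 3 (0.42 log units; beyond the scatter)) and relative to hydrogen (a 2.4-fold higher number from compound 1 to compound 3 (0.37 log units; beyond the scatter)). Methoxy and hydrogen stand within the scatter of each other, so of these three groups only fluoro moves the number beyond the scatter. Nothing measured here accounts for this shift. Going by these compounds, whether a chloro, a hydroxyl or an amine at this carbon would follow fluoro or methoxy stays open. So does whether fluoro has the same effect on the other carbons of this six-membered ring.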